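This account rests on a few compounds, and the source may have more. Where it says the series, first, only, none or still open, it means among the compounds named here.

Among the compounds with values here, in a functional assay on KYSE-450 cells (Homo sapiens) for inhibition, read by MTT assay, with a stated time of 48 h (a lower number here means a stronger inhibitor, a higher number a weaker inhibitor), only two compounds have a number so far. Compound 1 (`COc1ccc(CN(C(=O)C(C)Br)c2cc(OC)c(OC)c(OC)c2)cc1O`) gives 160 nM, while compound 2 (`COC(=O)c1cc(CNc2cc(OC)c(OC)c(OC)c2)ccc1OC`) gives 41100 nM. Compound 2 thus holds the higher of the two numbers, and its gap to compound 1 lies well beyond the scatter. Compound 3 (`COc1ccc(CNc2cc(OC)c(OC)c(OC)c2)cc1N`) is still to be measured. It has amino in place of methoxycarbonyl on an aromatic carbon, ortho to a methoxy group, compared with compound 2: amino in place of methoxycarbonyl on an aromatic carbon. Within the data shown here, no measured pair differs in one place only, so there is no direct precedent for this change. Since compound 2 stands at 41100 nM, a moderate move towards a lower number in this assay, beyond the scatter, is expected. The expected size of this move is a 5.1-fold lower number from compound 2 to compound 3 (0.71 log units; beyond the scatter). For compound 3 the estimated value is 8000 nM, with an expected range of 1500 nM to 40000 nM.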

Compound 3, half-maximal inhibitory concentration: 2210 nM
The estimate for compound 3 lay 3.6-fold (0.56 log units) above the measured number; the range from low to high includes it.
By their numbers in this assay, from the lowest: compound 1; then compound 3; then compound 2.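

In this assay, within the data shown here, replacing methoxycarbonyl with amino on this aromatic carbon, ortho to a methoxy group and meta to a large group, gives a 19-fold lower number from compound 2 to compound 3 (1.27 log units; beyond the scatter) and provides the first step in which only one place changes. The step shows that this position is sensitive to the group it carries, since the change moves the number well beyond the scatter. One step cannot separate the effect of losing methoxycarbonyl from that of gaining amino, and nothing at hand explains why the step is so large.

A carboxylic acid, a hydroxyl group or a methyl group on the same carbon would help to show how far the step depends on amino itself. Going by these compounds, it also remains open whether amino would give a similar step on the core of compound 1.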